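Trimming One Ester from an L-Selectin Binder

A few compounds are considered here, and "the series" means these few. Any claim that something is new, unique, unknown or untested is made for them only; others in the source may bear on it.

Measured so far:
compound 1, `CCCCCCCCCCOc1cc(OCCCCCCCCCC)cc(OCCCCCC(=O)N(c2ccc(C(=O)OC)cc2)c2ccc(C(=O)OC)c(C(=O)OC)c2)c1`: 95%
compound 2, `CCCCCCCCCCOc1cc(OCCCCCCCCCC)cc(OCCCCCCO/N=C(/c2ccc(C(=O)O)cc2)c2cccc(C(=O)O)c2)c1`: 50%

Both compounds share the same long-chain-decorated core and were tested in an assay on isolated protein for binding affinity to L-selectin (Homo sapiens), read by ELISA, tested at 500 uM; a lower number here means less inhibition, a higher number more inhibition at the concentration tested (going by the name of the read-out). Compound 1 stands highest of the two numbers, giving 95%. Its nearest companion, compound 2, gives 50%, a number that lies well below it and beyond the usual scatter of such a measurement. Compound 2 differs from compound 1 in several places at once, so nothing can be said about which of those changes matters; only the two values themselves are known.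

The next compound, compound 3, is `CCCCCCCCCCOc1cc(OCCCCCCCCCC)cc(OCCCCCC(=O)N(c2ccc(C(=O)OC)cc2)c2ccc(C(=O)OC)cc2)c1`. It differs from compound 1 in a single place: hydrogen in place of methoxycarbonyl on an aromatic carbon. Among the measured compounds shown here, no step of this kind has been measured yet, so its size can only be guessed. Taking a group away from a compound whose number in this assay is already high leaves little room upward; a modest loss is the more likely direction, though a step within the scatter would not be surprising.

On that basis compound 3 is expected to give about 85%, within a range of 60% to 98% in this assay, which corresponds to an expected step of a number 10 percentage points lower from compound 1 to compound 3 (within the scatter).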

Compound 3, a percentage reported as inhibition, at one concentration (the size of the read-out at that concentration, not a potency): 16%
The estimate for compound 3 lay 69 percentage points above the measured number; measured number outside the range, below it.
By their numbers in this assay, from the lowest: compound 3; then compound 2; then compound 1.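

In this assay, putting hydrogen in place of one methoxycarbonyl group gives a number 79 percentage points lower from compound 1 to compound 3 (beyond the scatter), so a single group on an otherwise unchanged compound accounts for most of the inhibition seen at the tested concentration. Among the compounds shown here, this is the first comparison here that differs in one place, and it ties a large loss to a specific aromatic carbon, ortho to a methoxycarbonyl group and meta to a large group, which the comparison with compound 2 could not do. Nothing at hand explains why this change costs so much.

As far as these compounds go, it remains open whether a carboxylic acid, a primary amide or a simple methyl group on this same carbon would keep the number close to that of compound 1 at 95% or leave it close to that of compound 3 at 16%. Equally open, from the compounds shown here alone, is how much the methoxycarbonyl groups still present in compound 3 contribute, and whether an amine in place of either would bring a step of similar size.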